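Longer chains on the sulfur of a chloromethyl ketone

The source may report more compounds than this note shows. Statements on the series, on what has been measured and on what is new or still open speak of the compounds shown alone.

Measured so far:
compound 1, `CCCCCSC[C@H](NC(C)=O)C(=O)CCl`: 5400 nM
compound 2, `CCCCCCSC[C@H](NC(C)=O)C(=O)CCl`: 700 nM
compound 3, `CCCCCCCCCCCSC[C@H](NC(C)=O)C(=O)CCl`: 3000 nM

In a functional assay on MOLT-3 cells (Homo sapiens) (on this read-out lower numbers stand for stronger inhibition and higher numbers for weaker inhibition), compound 1 gives the highest of the three numbers, so it is the weakest inhibitor shown. Compound 2 sits furthest from it, with a 7.7-fold lower number from compound 1 to compound 2 (0.89 log units; beyond the scatter), while compound 3 sits nearest, with a 1.8-fold lower number from compound 1 to compound 3 (0.26 log units; within the scatter). Between the two larger compounds the step is a 4.3-fold higher number from compound 2 to compound 3 (0.63 log units; beyond the scatter).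

Compound 4, `CCCCCCCCCCCCSC[C@H](NC(C)=O)C(=O)CCl`, differs from compound 1 by heptyl in place of hydrogen on a saturated chain carbon, five bonds along the chain from a sulfur. For the measured compounds named here, the steps that bear on it are the two extensions of the same chain from compound 1: the short extension to compound 2 brought a modest gain, whereas the long extension to compound 3 stayed within the scatter. Compound 4 extends the chain further still, so the nearer comparison is compound 3, and the number is expected to stay close to compound 1, with a step of about a 1.5-fold lower number from compound 1 to compound 4 (0.19 log units; within the scatter). The estimate for compound 4 in this assay is 3500 nM, between 1200 nM and 10000 nM.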

Compound 4, half-maximal inhibitory concentration: 2300 nM
The estimate for compound 4 lay 1.5-fold (0.18 log units) above the measured number; measured number inside the range.
By their numbers in this assay, from the lowest: compound 2; then compounds 4, 3 and 1 (each within the scatter of the next, the first and the last beyond it).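

Heptyl in place of hydrogen gives a 2.3-fold lower number from compound 1 to compound 4 (0.37 log units; beyond the scatter) in this assay, so a chain this long still holds a gain over compound 1. Methyl in place of hydrogen at the far end of the long chain gives a 1.3-fold lower number from compound 3 to compound 4 (0.12 log units; within the scatter), so the size of this step depends on the chain that receives it: the same change on two cores in this assay, a 7.7-fold lower number (0.89 log units; beyond the scatter) from compound 1 to compound 2 and a 1.3-fold lower number (0.12 log units; within the scatter) from compound 3 to compound 4, 5.9-fold (0.77 log units) apart, beyond the scatter of two such steps Hexyl in place of hydrogen now brings a 3.3-fold higher number from compound 2 to compound 4 (0.52 log units; beyond the scatter), and this change also depends on its starting chain: the same change on two cores in this assay, a 1.8-fold lower number (0.26 log units; within the scatter) from compound 1 to compound 3 and a 3.3-fold higher number (0.52 log units; beyond the scatter) from compound 2 to compound 4, 5.9-fold (0.77 log units) apart, beyond the scatter of two such steps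

The compounds shown leave open how the number moves for chains of intermediate length, such as an octyl chain on the sulfur. They also leave open whether a chain ending in an amine or a carboxylic acid would follow the plain carbon chains.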